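The source may hold more compounds than are shown below. What is called first, only, known or untested is meant among the compounds shown, and "the series" means these compounds.

Compound 1 `O=C(Nc1cccc2cn[nH]c12)N1CCN(Cc2cccc(Oc3ccc(Cl)cc3)c2)CC1` is the reference point of this set: in an assay on isolated protein for inhibition of Fatty-acid amide hydrolase 1 (Homo sapiens), with a stated time of 60 min (on this read-out lower numbers stand for stronger inhibition and higher numbers for weaker inhibition), compound 1 gives 1300 nM, the highest of the two numbers recorded, with compound 3 nearest at a lower value. Compound 3 `O=C(Nc1cccn2ccnc12)N1CCN(Cc2cccc(Oc3ccc(Cl)cc3)c2)CC1` gives 310 nM in this assay. Compound 2 `O=C(Nc1cn2ccccc2n1)N1CCN(Cc2cccc(Oc3ccc(Cl)cc3)c2)CC1` reaches only the limit of this assay, reported as > 10000 nM (the limit of > 10000 nM in this assay, at which 1 of the 3 values shown sits). Compound 4 `O=C(Nc1ccn2ccnc2c1)N1CCN(Cc2cccc(Oc3ccc(Cl)cc3)c2)CC1` has not yet been measured. It differs from compound 1 in one place: a group of 9 heavy atoms (7 carbon, 2 nitrogen; one five-membered aromatic ring with 2 hetero atoms, one six-membered aromatic ring with 1 hetero atom) in place of a group of 9 heavy atoms (7 carbon, 2 nitrogen; one five-membered aromatic ring with 2 hetero atoms, one six-membered aromatic ring of carbon only), on an amide-type nitrogen. Two measured steps involve the same kind of exchange on the same amide-type nitrogen and point in opposite directions: a 4.2-fold lower number from compound 1 to compound 3 (0.62 log units; beyond the scatter), whereas an at least 7.6-fold higher number from compound 1 to compound 2 (0.88 log units; beyond the scatter). Compound 4 bears an entering group of the same kind as compound 3, but as a different isomer, so the gain seen with compound 3 is not assured and the loss seen with compound 2 remains possible. A small move towards a higher number is expected, a 1.5-fold higher number from compound 1 to compound 4 (0.19 log units; within the scatter). For compound 4 an estimate of 2000 nM in this assay is made, with a range from 500 nM to 8000 nM.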

Compound 4, half-maximal inhibitory concentration: 33 nM
Compound 4: middle estimate off by 61-fold (1.78 log units), on the high side, and the stated range ends above it.
By their numbers in this assay, from the lowest: compound 4; then compound 3; then compound 1. At a limit, above all of these: compound 2.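

In this assay, this position on the amide-type nitrogen allows a far larger gain than compound 3 indicated, with a 39-fold lower number from compound 1 to compound 4 (1.60 log units; beyond the scatter), and the exchange between two groups of the same atoms, joined differently, still gives a 9.4-fold lower number from compound 3 to compound 4 (0.97 log units; beyond the scatter). The entering group of compound 4 has no hydrogen-bond donor, whereas 1H-indazol-7-yl has one, so a low number in this series does not require that donor. The widest step, an at least 300-fold lower number from compound 2 to compound 4 (2.48 log units; beyond the scatter), starts from a limit and not a number: the limit of > 10000 nM in this assay, at which 1 of the 4 values shown sits.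

Going by these compounds, what in the joining of the atoms sets the size of these steps stays open. Also open, on these data alone, is whether the low number of compound 4 survives a methyl group, a fluorine atom or a nitrile on its entering group.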